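The source may report more compounds than this note shows. Statements on the series, on what has been measured and on what is new or still open speak of the compounds shown alone.

Compound 1 `O=C(Nc1cccc(-c2cccc(F)c2)c1)C(Cl)Cl`: > 50000 nM
Compound 2 `CSc1cccc(-c2cc(NC(=O)C(Cl)Cl)cc(-c3cccc(SC)c3)c2)c1`: > 30000 nM
Compound 3 `Cc1cccc(-c2cccc(NC(=O)C(Cl)Cl)c2)c1`: not yet measured

In a functional assay on NCI-H460 cells (Homo sapiens) for cytotoxicity, read by MTT assay, with a stated time of 68 h (on this read-out higher numbers stand for weaker inhibition and lower numbers for stronger inhibition), compound 1 gives > 50000 nM, which is a limit of the assay and not a number. Compound 2 gives > 30000 nM, and this too is a limit. Compound 1 therefore has no exact position on the scale, and neither measured compound provides a number to compare with it.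

Compound 3 has methyl in place of fluoro on an aromatic carbon of the same core, at a position on a six-membered aromatic ring of carbon only, meta to a large group: methyl in place of fluoro on an aromatic carbon. Going by the values given here, no pair of measured compounds differs in just one place, so the data offer no direct guide to this step. The expected at least 1.2-fold lower number from compound 1 to compound 3 (0.09 log units; that floor lies within the scatter) is none beyond the usual scatter, an expectation that rests on compound 1, with its limit of > 50000 nM. For compound 3, the estimated value is 40000 nM, with an expected range from 15000 nM to 80000 nM.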

Compound 3, half-maximal inhibitory concentration: 24300 nM
Beside the measured number, compound 3's estimate is 1.6-fold (0.22 log units) above it; low and high end bracket the measured number.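

In this assay, placing methyl instead of fluoro on the aromatic carbon, meta to a large group, gives an at least 2.0-fold lower number from compound 1 to compound 3 (0.31 log units; beyond the scatter). Going by these compounds alone, this is the first direct sign that this position responds to a change of group: a swap of one heavy atom for another is enough to move the cytotoxicity read-out beyond the usual scatter, towards stronger inhibition. The step can only be stated as a floor, and its true size stays unknown, because compound 1 has a limit of the assay and not a number: the limit of > 50000 nM in this assay, at which 1 of the 3 values shown sits.

A single pair cannot show whether the methyl group itself drives the gain or whether the loss of fluoro matters more. As far as these compounds go, how an amine, a methoxy group or a longer chain such as ethyl would behave at this position also remains open.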